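A few compounds are considered here, and "the series" means these few. Any claim that something is new, unique, unknown or untested is made for them only; others in the source may bear on it.

In a functional assay on HEK293 cells for agonist activity at probable G-protein coupled receptor 27 (Homo sapiens), read by a luciferase reporter and beta-arrestin recruitment, with a stated time of 10 min (a lower number here means that less compound is needed, a higher number that more compound is needed for the effect), compound 3 `O=C(Nc1ccc(S(=O)(=O)Nc2ccccc2)cc1)c1ccc(I)cc1F` stands highest of the two numbers measured, with 5130 nM. Its nearest neighbour is compound 2 `O=C(Nc1ccc(S(=O)(=O)Nc2ccccc2)cc1)c1ccc(Br)cc1F`, which gives 479 nM. Compound 1 `O=C(Nc1ccc(Cl)cc1Cl)c1ccc(S(=O)(=O)Nc2ccccc2)cc1` sits at the limit of > 100000 nM in this assay, at which 1 of the 3 values shown sits; its value > 100000 nM is a limit of the assay, not a number. Compound 4 `Cc1cc(Cl)ccc1C(=O)Nc1ccc(S(=O)(=O)Nc2ccccc2)cc1` has not yet been measured; it differs from compound 3 by 4-chloro-2-methylphenyl in place of 2-fluoro-4-iodophenyl on a carbonyl carbon. Within the data shown here, only one measured step touches this part of the molecule: an 11-fold higher number from compound 2 to compound 3 (1.03 log units; beyond the scatter), in which a change of halogen on the same ring moved the number by a large amount. Among the measured compounds shown here, compound 4 again removes the iodine, this time in favour of chlorine, and also exchanges fluorine for methyl, so a movement back toward the number of compound 2 is expected; the second change has no measured counterpart, which widens the range. Compound 4 is therefore expected to show the step of a 5.1-fold lower number from compound 3 to compound 4 (0.71 log units; beyond the scatter). For compound 4 the estimated value is 1000 nM, likely between 150 nM and 7000 nM.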

Compound 4, half-maximal effective concentration: 912 nM
The estimate for compound 4 lay 1.1-fold (0.04 log units) above the measured number, and the stated range covers the measured number.
By their numbers in this assay, from the lowest: compounds 2 and 4 (each within the scatter of the next); then compound 3. At a limit, above all of these: compound 1.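

Replacing the whole ring gives a 5.6-fold lower number from compound 3 to compound 4 (0.75 log units; beyond the scatter) in this assay, so a ring carrying no iodine again gives a lower number than compound 3. The further step, a 1.9-fold higher number from compound 2 to compound 4 (0.28 log units; within the scatter), shows that 4-chloro-2-methylphenyl and 4-bromo-2-fluorophenyl cannot be told apart at this place on the carbonyl carbon. Among these three compounds, a methyl group can therefore stand where the others carry fluorine without a readable difference from compound 2, and compound 3 remains the one with the higher number.

Going by these compounds, compound 4 changes two substituents at once, so the share of each in its step stays open, as does the outcome with a methoxy group or an amine on this ring. Nothing measured here gives a reason for these steps.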